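The source may hold more compounds than are shown below. What is called first, only, known or untested is meant among the compounds shown, and "the series" means these compounds.

Measured so far in a toxicity assay on MDCK cells (Canis lupus familiaris) for cytotoxicity, read by crystal violet staining, with a stated time of 48 h; a lower number here means that less compound is tolerated, a higher number that more compound is tolerated:
- compound 1 `CCc1ccc2[nH]c(=O)c(CN(Cc3ccc(F)cc3)Cc3ccc(C(C)(C)C)cc3)cc2c1` gives > 33000 nM, a limit of the assay.
- compound 2 `CCc1ccc2[nH]c(=O)c(CN(CCCO)Cc3ccc(C(C)(C)C)cc3)cc2c1` gives > 10000 nM, a limit of the assay.
- compound 3 `CCc1ccc2[nH]c(=O)c(CN(Cc3ccc(OC(F)F)cc3)Cc3ccc(C(C)(C)C)cc3)cc2c1` gives > 5000 nM, a limit of the assay.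

Compound 3 thus stands only at a limit, as do the other two values. None of the steps is readable: a step that the two limits leave unreadable from compound 1 to compound 2, a step that the two limits leave unreadable from compound 1 to compound 3 and a step that the two limits leave unreadable from compound 2 to compound 3 are all hidden by the limit of > 10000 nM in this assay, at which 1 of the 3 values shown sits, the limit of > 33000 nM in this assay, at which 1 of the 3 values shown sits, and (the limit of > 5000 nM in this assay, at which 1 of the 3 values shown sits). The next change is 1-(4-fluorophenyl)ethyl in place of 4-(difluoromethoxy)benzyl on an amine nitrogen. Among the measured compounds shown here, no measured step bears on it, and all three values sit at limits, so no step beyond the scatter is expected in this assay in either direction. Compound 4 `CCc1ccc2[nH]c(=O)c(CN(Cc3ccc(C(C)(C)C)cc3)C(C)c3ccc(F)cc3)cc2c1` is therefore expected at 30000 nM (range 8000 nM to 100000 nM), most likely again as a limit, an expected step that the limit leaves unreadable from compound 3 to compound 4.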

Compound 4, half-maximal cytotoxic concentration: 2800 nM
Compound 4: the middle estimate sits 11-fold (1.03 log units) above what was measured; measured number below the stated range.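

Among the compounds shown, only compound 4 gives a number rather than a limit in this assay. At the saturated chain carbon bound to the amine nitrogen and an aromatic carbon, adding methyl gives an at least 11-fold lower number from compound 1 to compound 4 (1.07 log units; beyond the scatter), so this single change is enough to bring the series off its limits. The other two comparisons, on the amine nitrogen, give an at least 3.5-fold lower number from compound 2 to compound 4 (0.55 log units; beyond the scatter) and an at least 1.7-fold lower number from compound 3 to compound 4 (0.25 log units; that floor lies within the scatter).

The steps among compound 1, compound 2 and compound 3 cannot be read. As far as these compounds go, whether an ethyl or a longer chain in place of that methyl gives a similar drop remains open.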